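The source may hold more compounds than are shown below. What is called first, only, known or untested is meant among the compounds shown, and "the series" means these compounds.

Measured so far:
compound 1 `NC/C(=C\c1ccccc1)C(=O)O`: -2.4%
compound 2 `N#C/C(=C\c1ccccc1)C(=O)OC1CCCCC1`: 7.1%

In a functional assay on the whole organism (strain CD1) for inhibition, with Mus musculus as the target, with stated times of 15 min and 20 min, at a dose of 10 mg/kg by the subcutaneous route (a lower number here means less inhibition, a higher number more inhibition at the dose given (going by the name of the read-out)), compound 1 gives -2.4%, and compound 2 gives 7.1%. Of the two numbers compound 2 holds the larger, yet its gap to compound 1 lies within the usual scatter, so the two compounds are not told apart by these data. Compound 3 `N#C/C(=C\c1ccoc1)C(=O)OC1CCCCC1` differs from compound 2 in one place: furan-3-yl in place of phenyl on a double-bonded chain carbon bound to a double-bonded chain carbon. Going by the values given here, no step between measured compounds in this assay is at hand, and both measured numbers sit close to zero. The expected step is therefore small, a number 2.1 percentage points lower from compound 2 to compound 3 (within the scatter), none beyond the scatter. Compound 3 is estimated to give 5%, in the range -10% to 20%.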

Compound 3, a percentage reported as inhibition, in the whole organism at one dose (the size of the read-out at that dose, not a potency): 91.2%
Estimate against measurement, compound 3: 86.2 percentage points below; measured number above the stated range.
By their numbers in this assay, from the lowest: compounds 1 and 2 (each within the scatter of the next); then compound 3.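

With the ester and nitrile kept, the group on a double-bonded chain carbon bound to a double-bonded chain carbon proves decisive in this assay: furan-3-yl in place of phenyl gives a number 84.1 percentage points higher from compound 2 to compound 3 (beyond the scatter) and so lifts the read-out clear of the near-zero values seen so far. The earlier compounds shown here, lying within the scatter of each other, gave no sign that this position could matter so much.

As far as these compounds go, whether thiophen-3-yl or furan-2-yl would serve as furan-3-yl does, and whether a carboxylic acid could replace the ester with furan-3-yl kept, stays open. Nothing at hand accounts for the size of this step.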